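Swapping a chlorophenyl for naphthyl on a hydantoin hydroxamate

The compounds below may be only part of what the source reports. "The series", "measured", "known", "first", "only" and "open" are said of these compounds alone.

Measured compounds:
compound 1 `CCCN1CC(=O)N(Cc2ccc(C(=O)NO)cc2)C1=O`: 53.4 nM
compound 2 `Cc1ccc(CN2CC(=O)N(Cc3ccc(C(=O)NO)cc3)C2=O)cc1`: 17.6 nM
compound 3 `O=C(NO)c1ccc(CN2C(=O)NC(Cc3ccc(Cl)cc3)(c3ccccc3)C2=O)cc1`: 54 nM

All three were tested in an assay on isolated protein for inhibition of protein deacetylase HDAC6 (Homo sapiens), read by fluorescence, with stated times of 10 min and 2 h; a higher number here means a weaker inhibitor, a lower number a stronger inhibitor. Compound 3 gives the highest of the three numbers. Its nearest neighbour is compound 1, whose value sits within the scatter of it, so the two cannot be told apart. For the measured compounds named here, compound 2 lies beyond the scatter below compound 3, and the only step between single-point neighbours, a 3.0-fold lower number from compound 1 to compound 2 (0.48 log units; beyond the scatter), shows that replacing a small alkyl group by an aromatic ring at a ring-bound chain carbon gave a modest gain.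

Compound 4 `O=C(NO)c1ccc(CN2C(=O)NC(Cc3ccc4ccccc4c3)(c3ccccc3)C2=O)cc1` is not yet measured. It differs from compound 3 in one place: naphthalen-2-yl in place of 4-chlorophenyl on a saturated chain carbon bound to a saturated ring carbon. Going by the values given here, no measured pair covers this exact exchange. The step from compound 1 to compound 2 is the closest guide, since it too enlarges the group on a saturated chain carbon, but it changes an alkyl into an aryl rather than one aryl into another, so it is only a loose hint. A step of similar or smaller size, toward a lower number, is therefore expected for a 1.8-fold lower number from compound 3 to compound 4 (0.26 log units; within the scatter), with the chance of no change beyond the scatter. The estimate for compound 4 in this assay is 30 nM, within a range from 12 nM to 90 nM.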

Compound 4, half-maximal inhibitory concentration: 74.6 nM
Beside the measured number, compound 4's estimate is 2.5-fold (0.40 log units) below it; low and high end bracket the measured number.
By their numbers in this assay, from the lowest: compound 2; then compounds 1, 3 and 4 (each within the scatter of the next).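

In this assay, putting naphthalen-2-yl in place of 4-chlorophenyl on a saturated chain carbon bound to a saturated ring carbon gives a 1.4-fold higher number from compound 3 to compound 4 (0.14 log units; within the scatter). This position therefore tolerates a clear enlargement of the group, from 7 heavy atoms in one aromatic ring to 10 heavy atoms in 2 aromatic rings, with no change that can be told from the scatter, and the loss of the chlorine leaves no resolved mark either. Nothing measured on these compounds offers an explanation for this flat result.

The exchange alters ring count and chlorine at once, so the pair cannot show what each change does alone, and a plain phenyl or a 4-methylphenyl at this place would help to separate the two. From the compounds shown here alone, it also remains open whether this tolerance extends to groups of a different kind on the same chain carbon, such as a carboxylic acid, an amine like dimethylamino on the ring, or a longer chain of saturated carbons ending in a phenyl.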